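The compounds below may be only part of what the source reports. "The series", "measured", "known", "first", "only" and "open" are said of these compounds alone.

Compound 1 `CCC(=O)Nc1cccc(S(=O)(=O)Oc2ccccc2C(C)C)c1` and compound 2 `CCCCCC(=O)Nc1cccc(S(=O)(=O)Oc2ccccc2C(C)C)c1` share a core that differs only in the amide chain. In a functional assay on HT-29 cells (Homo sapiens) for antiproliferative activity, read by sulforhodamine B assay, with a stated time of 48 h (on this read-out higher numbers stand for weaker inhibition and lower numbers for stronger inhibition), compound 1 gives 22000 nM, and in this assay compound 2 gives 19000 nM. The step of a 1.2-fold lower number from compound 1 to compound 2 (0.06 log units; within the scatter) puts the two within the scatter of each other, so compound 2 stands lowest of the two numbers only by a margin that means nothing on its own.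

Compound 3 `CC(C)c1ccccc1OS(=O)(=O)c1cccc(NC(=O)C(C)(C)C)c1` takes the next step from compound 2: tert-butyl in place of pentyl on a carbonyl carbon. Going by the values given here, the one measured step that bears on this change is a 1.2-fold lower number from compound 1 to compound 2 (0.06 log units; within the scatter), which shows that lengthening the chain on the carbonyl carbon left this assay unmoved. Shortening and branching it to tert-butyl is a change of similar kind, and there is no measured step that points to a gain or a loss. Compound 3 is therefore expected to show a step of a 1.2-fold higher number from compound 2 to compound 3 (0.08 log units; within the scatter), that is, none beyond the scatter. In this assay compound 3 is estimated at 23000 nM, with a range from 8000 nM to 65000 nM.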

Compound 3, half-maximal inhibitory concentration: 19000 nM
The estimate for compound 3 lay 1.2-fold (0.08 log units) above the measured number; low and high end bracket the measured number.
By their numbers in this assay, from the lowest: compounds 2, 3 and 1 (each within the scatter of the next).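

In this assay, tert-butyl in place of pentyl on a carbonyl carbon (no change at the digits printed from compound 2 to compound 3 (within the scatter)) and tert-butyl in place of ethyl on the same carbon (a 1.2-fold lower number from compound 1 to compound 3 (0.06 log units; within the scatter)) both stay within the scatter. The earlier pair compared only the unbranched ethyl and pentyl chains, whereas these steps show that a branched chain at this position also gives a reading that cannot be told apart from either of them, so all three compounds form one flat set in this assay. Nothing measured here accounts for this flat reading, and no evidence bears on it.

From the compounds shown here alone, all three groups at this position are plain carbon chains, so it remains open whether a markedly longer chain, or a chain carrying an amine or a carboxylic acid, would move the number beyond the scatter. The compounds shown also differ only in the amide chain, which leaves open how far the number depends on the rest of the shared core, and whether any change there would shift the activity in this assay.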